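This account rests on a few compounds, and the source may have more. Where it says the series, first, only, none or still open, it means among the compounds named here.

Measured compounds in an ADME assay on S9 fraction from liver (Rattus norvegicus) for metabolic stability, read by LC-MS, using NADPH, with a stated time of 30 min; on this read-out lower numbers stand for a less stable compound and higher numbers for a more stable compound:
- compound 1 `CCCCCCCCc1ccc(OCC(=O)Cn2ncnn2)cc1`: < 5%
- compound 2 `CCCCCCCCc1ccc(OCC(=O)Cn2nnc(-c3cccc(S(=O)(=O)N(C)C)c3)n2)cc1`: 9%

Compound 1 stands at the bottom of the two numbers in this assay; its value of < 5% is a limit of the assay and not a number, so its true position is known only as a range (the limit of < 5% in this assay, at which 1 of the 2 values shown sits). Compound 2 in this assay gives 9%. Within the data shown here, the step of a number at least 4 percentage points higher from compound 1 to compound 2 (that floor lies within the scatter) is the only measured step, carrying 3-(dimethylsulfamoyl)phenyl in place of hydrogen on an aromatic carbon.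

Compound 3 `CCCCCCCCc1ccc(OCC(=O)Cn2nnc(C(=O)O)n2)cc1` has not been measured. It differs from compound 1 as carboxy in place of hydrogen on an aromatic carbon. Among the measured compounds shown here, no measured step bears on a carboxy group; the step from compound 1 to compound 2 is the nearest comparison and only shows that substitution at this aromatic carbon left the value near the limit. For compound 3 in this assay a step of a number at least 3 percentage points higher from compound 1 to compound 3 (that floor lies within the scatter) is therefore expected, small and likely within the scatter. The estimate for compound 3 in this assay is 8%, with a range from 0% to 25%, and a fair chance that only a limit is reported.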

Compound 3, percent of the compound remaining: 52%
The estimate for compound 3 lay 44 percentage points below the measured number, outside the stated range (above it).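

In this assay, the aromatic carbon of the five-membered aromatic ring with 4 nitrogen proves able to carry a large change, which the earlier pair did not show: carboxy in place of hydrogen gives a number at least 47 percentage points higher from compound 1 to compound 3 (beyond the scatter). The outcome depends on the group placed there and not on substitution at this carbon as such, as carboxy in place of 3-(dimethylsulfamoyl)phenyl gives a number 43 percentage points higher from compound 2 to compound 3 (beyond the scatter). Compound 1 sits at a limit of the assay, so the step that starts from it is a floor and its full size stays unknown: the limit of < 5% in this assay, at which 1 of the 3 values shown sits.

The compounds shown leave open whether this gain belongs to the carboxy group alone or would also come with a methyl ester, a primary amide or a hydroxymethyl group on the same carbon. They also leave open whether a step of this size would hold on a core with a shorter alkyl chain in place of the long chain shared by all of these compounds.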